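The compounds below may be only part of what the source reports. "The series", "measured", "known", "first", "only" and "open" are said of these compounds alone.

Measured compounds:
compound 1 `Nc1ccccc1/N=C\c1cc(=O)oc2cc(OCc3ccccc3)ccc12` — in a functional assay, read by spectrophotometry, with a stated time of 5 min (on this read-out lower numbers stand for stronger inhibition and higher numbers for weaker inhibition), compound 1 gives 217000 nM
compound 2 `O=c1cc(/C=N\c2ccccc2O)c2ccc(OCc3ccccc3)cc2o1` — in this assay compound 2 gives 469000 nM
compound 3 `O=c1cc(/C=N\c2ccc(O)cc2)c2c(OCc3ccccc3)cc(OCc3ccccc3)cc2o1` — in this assay compound 3 gives 249000 nM

All three numbers sit at the weak end of what this assay resolves. Compound 3 holds the second highest of the three numbers; its gap to compound 1 is within the scatter, and its gap to compound 2 is also within the scatter, so no order among the three can be read from these values. For the measured compounds named here, the only step between neighbours that differ in one place is a 2.2-fold higher number from compound 1 to compound 2 (0.33 log units; beyond the scatter), a modest shift, beyond the scatter, when hydroxy replaces amino on an aromatic carbon.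

Compound 4 `O=c1cc(/C=N\Nc2ccccc2)c2c(OCc3ccccc3)cc(OCc3ccccc3)cc2o1` is not yet measured. It differs from compound 3 by anilino in place of 4-hydroxyphenyl on a double-bonded nitrogen. Going by the values given here, no measured pair covers this exact exchange; the step from compound 1 to compound 2 is the nearest precedent, since it also swaps a donor group on the ring attached to the double-bonded nitrogen, and it moved the number only modestly. The expectation for compound 4 in this assay is therefore a small step, most likely within the scatter, with no firm direction: a 1.1-fold lower number from compound 3 to compound 4 (0.05 log units; within the scatter) is the estimated move. Compound 4 is thus expected to give about 220000 nM, with a plausible range from 80000 nM to 600000 nM.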

Compound 4, half-maximal inhibitory concentration: 303000 nM
For compound 4 the middle estimate is 1.4-fold (0.14 log units) below the measured one; low and high end bracket the measured number.
By their numbers in this assay, from the lowest: compounds 1, 3, 4 and 2 (each within the scatter of the next, the first and the last beyond it).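

Exchanging 4-hydroxyphenyl for anilino on the double-bonded nitrogen gives, in this assay, a 1.2-fold higher number from compound 3 to compound 4 (0.09 log units; within the scatter), so this position tolerates an exchange in which an oxygen leaves and a nitrogen enters, with heavy-atom, donor and acceptor counts unchanged, without a readable change in the number. For the compounds shown here, this differs in size from the earlier hydroxy-for-amino exchange on a different core, a 2.2-fold higher number from compound 1 to compound 2 (0.33 log units; beyond the scatter), the only step here beyond the scatter, and it shows that the hydroxy of compound 3 can be lost, together with the other changes this exchange brings, with the number staying inside the scatter. Nothing available accounts for this result or says which feature of either group matters.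

As far as these compounds go, both compared groups carry an unsubstituted or singly hydroxylated aromatic ring, so it remains open whether a carboxylic acid, a morpholine or a plain alkyl chain on the double-bonded nitrogen would take the number out of this weak range. Also open, from the compounds shown here alone, is whether this tolerance holds on the core of compound 1, which carries one benzyloxy group where compound 3 carries two, or with a smaller alkoxy group such as methoxy in their place.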